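A few compounds are considered here, and "the series" means these few. Any claim that something is new, unique, unknown or untested is made for them only; others in the source may bear on it.

Compound 1 `C/N=C(/S)C1=CC(C)(C)Oc2ccc(C#N)cc21` carries a cyano group on its aromatic ring. In a functional assay (aorta) with Rattus norvegicus as the target (a lower number here means that less compound is needed, a higher number that more compound is needed for the effect), compound 1 gives 24.6 nM, the lowest of the two numbers in hand. Compound 2 `C/N=C(/S)C1=CC(C)(C)Oc2ccc(OC(C)=O)cc21` has acetoxy in place of that cyano; in this assay compound 2 gives 95.5 nM, so a 3.9-fold higher number from compound 1 to compound 2 (0.59 log units; beyond the scatter). Compound 3 `CCc1ccc2c(c1)C(/C(S)=N\C)=CC(C)(C)O2` differs from compound 1 in one place: ethyl in place of cyano on an aromatic carbon. Among the measured compounds shown here, only that one measured step bears on removing the cyano, and it raised the number modestly, so a similar or somewhat larger rise is expected here. For compound 3 the estimate is 150 nM, ranging from 50 nM to 600 nM, which means a 6.1-fold higher number from compound 1 to compound 3 (0.79 log units; beyond the scatter).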

Compound 3, half-maximal effective concentration: 324 nM
Compound 3: middle estimate off by 2.2-fold (0.33 log units), on the low side, and the stated range covers the measured number.
By their numbers in this assay, from the lowest: compound 1; then compound 2; then compound 3.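

In this assay, ethyl on this aromatic carbon does more than acetoxy did: the change is large (a 13-fold higher number from compound 1 to compound 3 (1.12 log units; beyond the scatter)) and ethyl also stands apart from acetoxy (a 3.4-fold higher number from compound 2 to compound 3 (0.53 log units; beyond the scatter)). This position therefore separates all three groups, with the number rising from cyano through acetoxy to ethyl and each gap beyond the scatter. No measurement here explains that order. On these data alone, whether an amine, a carboxylic acid or a longer chain such as butyl would fit this order remains open.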